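Replacing phenyl with iodo on a core that shows no inhibition

The source may hold more compounds than are shown below. What is called first, only, known or untested is meant among the compounds shown, and "the series" means these compounds.

Measured so far:
- compound 1, `Cc1nc(N)c2c(-c3ccccc3)cn([C@@H]3O[C@H](CO)[C@@H](O)[C@H]3O)c2n1`: > 20000 nM
- compound 2, `Nc1nc(N)c2c(-c3ccccc3)cn([C@@H]3O[C@H](CO)[C@@H](O)[C@H]3O)c2n1`: > 20000 nM

In a functional assay on HeLa S3 cells (Homo sapiens) for antiproliferative activity, read by XTT assay, with a stated time of 72 h (on this read-out higher numbers stand for weaker inhibition and lower numbers for stronger inhibition), compound 1 gives > 20000 nM, which is a limit of the assay rather than a number. In this assay compound 2 gives > 20000 nM, again a limit. Accordingly a step that the two limits leave unreadable from compound 1 to compound 2 cannot be read, and the only thing the two values share is the limit of > 20000 nM in this assay, at which 2 of the 2 values shown sit.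

Compound 3, `Cc1nc(N)c2c(I)cn([C@@H]3O[C@H](CO)[C@@H](O)[C@H]3O)c2n1`, differs from compound 1 by iodo in place of phenyl on an aromatic carbon. Within the data shown here, no measured step covers this change, and the one measured change, amino in place of methyl on an aromatic carbon, gives no readable size. With compound 1 sitting at the limit, the expectation for compound 3 is that this assay will most likely again report only a limit, and a step that the limit leaves unreadable from compound 1 to compound 3 is the estimated step. Compound 3 is expected at 30000 nM, within 6000 nM to 150000 nM.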

Compound 3, half-maximal inhibitory concentration: 4180 nM
Compound 3: middle estimate off by 7.2-fold (0.86 log units), on the high side; measured number below the stated range.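

In this assay, iodo in place of phenyl on this aromatic carbon gives an at least 4.7-fold lower number from compound 1 to compound 3 (0.67 log units; beyond the scatter), so the group at this position can decide whether the read-out moves off its limit. The change swaps a six-carbon ring for a single iodine atom, and it shows that the shared core can inhibit these cells, something the two phenyl compounds could not show. Compound 3 is the only one of the three with a measured number rather than a limit: the limit of > 20000 nM in this assay, at which 2 of the 3 values shown sit.

As far as these compounds go, whether this effect is particular to iodo stays open, since bromo, chloro or a short chain such as ethyl on the same carbon would be needed to tell. The step from methyl to amino still cannot be read, and how that change behaves alongside iodo is also unknown.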